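Methyl to Fluoro on the Aromatic Ring of Compound 1

The source may hold more compounds than are shown below. What is called first, only, known or untested is meant among the compounds shown, and "the series" means these compounds.

Measured compounds:
compound 1 `Cc1ccc(NS(=O)(=O)C2CCCCC2=O)c(C)c1` gives 0.52%
compound 2 `O=C1CCCCC1S(=O)(=O)Nc1ccccc1Cl` gives 1.98%

Both numbers come from a functional assay on Bel-7402 cells (Homo sapiens) for antiproliferative activity, read by sulforhodamine B assay, tested at 100 ug/mL; on this read-out higher numbers stand for more inhibition at the one concentration tested (going by the name of the read-out) and lower numbers for less inhibition. On the numbers shown, compound 1 holds the lower of the two, yet the gap to compound 2 sits within the usual scatter of this kind of measurement, so the two readings cannot be told apart; each shows hardly any inhibition at the single concentration tested. Within the data shown here, no pair of measured compounds differs in just one place, so there is no measured step to lean on.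

Compound 3 `Cc1cc(F)ccc1NS(=O)(=O)C1CCCCC1=O` has not been measured. It is derived from compound 1 by fluoro in place of methyl on an aromatic carbon; the group that leaves and the group that enters each count one heavy atom, and neither brings a hydrogen-bond donor or acceptor. With only the near-zero readings of compound 1 and compound 2 to go by, the step in this assay is expected to stay within the scatter, in no particular direction. Compound 3 is therefore estimated at 2%, with a likely range from -6% to 12%, which means an expected step of a number 1.5 percentage points higher from compound 1 to compound 3 (within the scatter).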

Compound 3, a percentage reported as inhibition, at one concentration (the size of the read-out at that concentration, not a potency): 3.22%
For compound 3 the middle estimate is 1.2 percentage points below the measured one, and the stated range covers the measured number.
By their numbers in this assay, from the lowest: compounds 1, 2 and 3 (each within the scatter of the next).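

Among these compounds, this is the one pair so far that differs in a single place, so it gives the series its only measured step: in this assay, fluoro in place of methyl, on the aromatic carbon para to a large group and meta to a methyl group, comes to a number 2.7 percentage points higher from compound 1 to compound 3 (within the scatter), which cannot be told apart from repeat-to-repeat variation. At this position, then, exchanging one single-atom group for the other leaves the reading indistinguishable from that of compound 1, and compound 3 joins the other compounds in showing hardly any inhibition at the one concentration tested. No measurement at hand bears on why these readings sit where they do.

Because every reading lies so close to zero, the compounds shown leave open whether this position matters at all, since a swap on a compound that barely inhibits has little room to reveal an effect. Also open, from the compounds shown here alone, is whether a larger or quite different group at this carbon, such as an amine, a carboxylic acid or a longer alkyl chain, or any change elsewhere on the shared core, would move the reading beyond the scatter.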